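The compounds below may be only part of what the source reports. "The series", "measured", "known", "first", "only" and "open" are said of these compounds alone.

Compounds measured in a physicochemical assay for lipophilicity, read by LC-MS, using the shake flask method, in phosphate buffer, measured as octanol-water partition, with a stated time of 2 h, at pH 7.4; on this read-out higher numbers stand for higher lipophilicity and lower numbers for lower lipophilicity:
- Compound 1 `O=C(O)c1cncc(-n2cc(CO[C@H]3O[C@H](CO)[C@@H](O)[C@H](O)[C@@H]3O)nn2)c1`: "not determined" (no result reported)
- Compound 2 `O=[N+]([O-])c1ccc(-n2cc(CCO[C@H]3O[C@H](CO)[C@@H](O)[C@H](O)[C@@H]3O)nn2)cc1`: -0.3
- Compound 3 `OC[C@H]1O[C@H](OCCc2cn(-c3ccncc3)nn2)[C@@H](O)[C@@H](O)[C@@H]1O`: < -1.5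

Compound 3 gives < -1.5, which is a limit of the assay and not a number. Compound 4 `OC[C@H]1O[C@H](OCCc2cn(-c3ccc(F)cc3)nn2)[C@@H](O)[C@@H](O)[C@@H]1O` differs from it in one place, with 4-fluorophenyl in place of pyridin-4-yl on an aromatic nitrogen.

Among the measured compounds shown here, one measured step bears on this change at the same place, a number at least 1.20 log units lower from compound 2 to compound 3 (beyond the scatter), a large step that brought in pyridin-4-yl in place of 4-nitrophenyl. Compound 4 goes the other way, back to a six-membered aromatic ring of carbon only, so a step of similar size in the opposite direction, beyond the scatter, is expected. The nearest guide is compound 2 at -0.3, and compound 4 is expected to land close to it in this assay.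

The expected step is a number at least 1.30 log units higher from compound 3 to compound 4 (beyond the scatter). For compound 4 the estimate is -0.2, with an expected range from -0.7 to 0.3.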

Compound 4, distribution coefficient: -0.21
Estimate against measurement, compound 4: 0.01 log units above, within the range that was stated.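

In this assay, 4-fluorophenyl in place of pyridin-4-yl on the aromatic nitrogen gives a number at least 1.29 log units higher from compound 3 to compound 4 (beyond the scatter), so a change at this position in the opposite direction to the earlier step is now also large. Fluoro in place of nitro on an aromatic carbon gives a number 0.09 log units higher from compound 2 to compound 4 (within the scatter), so 4-nitrophenyl and 4-fluorophenyl cannot be told apart on this read-out, while pyridin-4-yl stands apart from both. The full size of the step from pyridin-4-yl stays unknown because compound 3 gives a limit of the assay and not a number: the limit of < -1.5 in this assay, at which 1 of the 4 values shown sits.

From the compounds shown here alone, whether an amine or a methoxy group in place of fluoro would also stay within the scatter of compound 4 remains open. So does the effect of a longer chain on the ring atom that bears the large group.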